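Swapping the Pyrimidine Arm for a Methylimidazole

The source may report more compounds than this note shows. Statements on the series, on what has been measured and on what is new or still open speak of the compounds shown alone.

In a physicochemical assay for solubility, read by HPLC, using the shake flask method, measured as kinetic solubility, with a stated time of 2 h, at pH 7.4 (a lower number here means a less soluble compound, a higher number a more soluble compound), compound 3 `Cc1cc(NCc2ncccn2)n2nc(C)c(-c3ccccc3)c2n1` gives 37900 nM. Among the measurements that are plain numbers this is the lower one; compound 2 `Cc1cc(NCc2ccccn2)n2ncc(Br)c2n1` gives 89300 nM in this assay, a larger number, with the gap between the two beyond the usual scatter. Compound 1 `Cc1cc(NCc2ccccn2)n2ncc(-c3ccc(F)cc3)c2n1` gives < 5000 nM in this assay, which is a limit of the assay rather than a number (the limit of < 5000 nM in this assay, at which 1 of the 3 values shown sits). Among the measured compounds shown here, the single measured step, an at least 17-fold higher number from compound 1 to compound 2 (1.25 log units; beyond the scatter), concerns a change at a different place and so tells little about the step now in view. Compound 4 `Cc1cc(NCc2nccn2C)n2nc(C)c(-c3ccccc3)c2n1` differs from compound 3 by 1-methyl-1H-imidazol-2-yl in place of pyrimidin-2-yl on a saturated chain carbon bound to a nitrogen on an aromatic ring. For the measured compounds named here, no measured step bears on this exchange of one small aromatic ring for another of the same size, so the expectation is for a change that stays close to, or only modestly beyond, the scatter; the step from compound 3 to compound 4 is expected to be a 1.2-fold higher number from compound 3 to compound 4 (0.07 log units; within the scatter). For compound 4 the estimate in this assay is 45000 nM, with a range from 15000 nM to 140000 nM.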

Compound 4, solubility: 26900 nM
For compound 4 the middle estimate is 1.7-fold (0.22 log units) above the measured one; low and high end bracket the measured number.
By their numbers in this assay, from the lowest: compounds 4 and 3 (each within the scatter of the next); then compound 2. At a limit, below all of these: compound 1.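

In this assay, putting 1-methyl-1H-imidazol-2-yl in place of pyrimidin-2-yl gives a 1.4-fold lower number from compound 3 to compound 4 (0.15 log units; within the scatter), so this read-out does not separate the two rings at this place, even though a six-membered aromatic ring gives way to a five-membered one. Among the compounds shown here, the earlier compounds gave no reading here, as their one step concerns a different place on the shared core. No measured property shown accounts for this result.

Both rings have the same counts of heavy atoms, hydrogen-bond donors and acceptors, so the compounds shown test only a narrow exchange at this place. As far as these compounds go, it remains open whether a group of another kind on the saturated chain carbon, such as a dimethylamino group or a carboxylic acid, would move the number beyond the scatter.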